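The compounds below may be only part of what the source reports. "The series", "measured", "known", "first", "only" and "open" are said of these compounds alone.

In an ADME assay on CEM-SS cells (Homo sapiens) for cytotoxicity, read by XTT assay, with a stated time of 6 days (on this read-out lower numbers stand for higher toxicity in this test and higher numbers for lower toxicity in this test), compound 1 (`CCCC(=O)OCSc1ccccc1C(=O)NCCCC(N)=O`) stands at 56.6 uM and compound 2 (`CCCC(=O)OCSc1ccccc1C(=O)NCCCCC(N)=O`) at 51.7 uM while compound 3 (`CCCC(=O)OCSc1ccccc1C(=O)NCC(=O)OC`) gives 27.3 uM as the third number. Compound 3 stands apart beyond the scatter from compound 1 only. Between the two carbamoyl compounds the step is flat: a 1.1-fold lower number from compound 1 to compound 2 (0.04 log units; within the scatter) gives no separation.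

Compound 4 (`CCCC(=O)OCSc1ccccc1C(=O)N(C)CC(=O)NC`) is the next compound, and its change from compound 3 reads: methyl((methylcarbamoyl)methyl)amino in place of ((methoxycarbonyl)methyl)amino on a carbonyl carbon with the methoxycarbonyl end giving way to a methylcarbamoyl end. The closest guides are the two measured steps that set methoxycarbonyl against a carbamoyl chain end. These are a 2.1-fold lower number from compound 1 to compound 3 (0.32 log units; beyond the scatter) and a 1.9-fold lower number from compound 2 to compound 3 (0.28 log units; within the scatter) and both are modest. Read in reverse, they suggest a small rise in the number on going from the ester back to an amide. For the measured compounds named here, no measured compound carries the methyl((methylcarbamoyl)methyl)amino group, so that group as a whole remains untested and the range stays wide. The expected step is a 1.5-fold higher number from compound 3 to compound 4 (0.17 log units; within the scatter) and no large move is expected in this assay on this evidence. Compound 4 is estimated at 40 uM (expected range 18 uM to 85 uM).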

Compound 4, half-maximal toxic concentration: 62.5 uM
Compound 4: the middle estimate sits 1.6-fold (0.19 log units) below what was measured, and the stated range covers the measured number.
By their numbers in this assay, from the lowest: compounds 3, 2, 1 and 4 (each within the scatter of the next, the first and the last beyond it).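

Methyl((methylcarbamoyl)methyl)amino in place of ((methoxycarbonyl)methyl)amino on the carbonyl carbon gives, in this assay, a 2.3-fold higher number from compound 3 to compound 4 (0.36 log units; beyond the scatter) and this modest step removes the ester from the chain. The new group shows no separation from either carbamoyl chain, with a 1.2-fold higher number from compound 2 to compound 4 (0.08 log units; within the scatter) and a 1.1-fold higher number from compound 1 to compound 4 (0.04 log units; within the scatter) so a methylcarbamoyl end carrying an added methyl on the amino nitrogen reads the same in this test as the plain carbamoyl ends. Of the four compounds, only the methoxycarbonyl compound 3 separates beyond the scatter, and it does so from compound 1 and compound 4 but not from compound 2, while nothing at hand speaks to the cause of the step.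

The step to compound 4 changes the chain end and the amino nitrogen together, so ((methylcarbamoyl)methyl)amino without the added methyl would be needed to divide the step between the two changes. As far as these compounds go, a carboxylic acid at the chain end, or a primary amine in its place, is also open, as is whether a longer chain ending in methylcarbamoyl would stay level with compound 4.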